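Swapping an acetyl for a dichlorophenyl on the coumarin-type core

The source may hold more compounds than are shown below. What is called first, only, known or untested is meant among the compounds shown, and "the series" means these compounds.

Three compounds built around a shared core carrying a dithiolane-capped amide tail were tested in a functional assay on PC-12 cells (Rattus norvegicus) for cytotoxicity, read by MTT assay, with stated times of 3 h and 2 h, tested at 50 uM; a higher number here means a stronger effect of the compound at the concentration tested, a lower number a weaker effect. Compound 1, `O=C(CCCCC1CCSS1)NCc1cn(CCCOc2ccc3cc(C(=O)O)c(=O)oc3c2)nn1`, gives 73.5%. Compound 2, `COc1ccc(-c2cc3ccc(OCCCCn4cc(CNC(=O)CCCCC5CCSS5)nn4)cc3oc2=O)cc1`, gives 55.3%. Compound 3, `CC(=O)c1cc2ccc(OCCCCCn3cc(CNC(=O)CCCCC4CCSS4)nn3)cc2oc1=O`, gives 18.2%, the lowest of the three numbers: its nearest neighbour is compound 2, whose value lies higher by a margin beyond the scatter, and compound 1 lies further still above it, also beyond the scatter.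

Compound 4, `O=C(CCCCC1CCSS1)NCc1cn(CCCCCOc2ccc3cc(-c4ccc(Cl)c(Cl)c4)c(=O)oc3c2)nn1`, has not yet been measured. It differs from compound 3 in one place: 3,4-dichlorophenyl in place of acetyl on an aromatic carbon. Going by the values given here, no measured pair in this set differs in exactly one place, so the size of such a step is not known from direct comparison.

The account therefore rests on the values themselves. Compound 2, which also carries a six-membered aromatic ring of carbon only on its core, gives 55.3%, well above compound 3. On that basis the step is expected to go upward and beyond the scatter: the estimate implies a number 31.8 percentage points higher from compound 3 to compound 4 (beyond the scatter). Compound 4 is estimated at 50%, with a range from 25% to 75%.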

Compound 4, a percentage reported as activity, at one concentration (the size of the read-out at that concentration, not a potency): 66.2%
Compound 4: middle estimate off by 16.2 percentage points, on the low side, within the range that was stated.
By their numbers in this assay, from the lowest: compound 3; then compound 2; then compounds 4 and 1 (each within the scatter of the next).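

In this assay, going by these compounds alone, the change from acetyl to 3,4-dichlorophenyl on an aromatic carbon, two atoms from the ring oxygen, goes with a number 48 percentage points higher from compound 3 to compound 4 (beyond the scatter) and is the first step in the set that can be read directly. It shows that the read-out at the single concentration tested is sensitive to the group at this position, with the rest of the molecule unchanged. The measurements shown offer no account of why the read-out moves with this change.

The step replaces 3 heavy atoms without a ring by 8 heavy atoms with one six-membered aromatic ring of carbon only, so it cannot be divided between the ring and its two chlorine atoms: an unsubstituted phenyl or a 4-chlorophenyl at this position would be needed to separate them. Going by these compounds, whether an amine at the same position would give a read-out nearer compound 3 or compound 4 also remains open, as does whether the step would keep its size with a different chain linking the core to the triazole-bearing tail.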